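Removing a Ring Methyl from a Bicyclic Lactam Inhibitor

The compounds below may be only part of what the source reports. "The series", "measured", "known", "first", "only" and "open" are said of these compounds alone.

Of the compounds shown here, three have been measured in an ADME assay on cells for inhibition of cytochrome P450 11B1, mitochondrial (Homo sapiens), read by HTRF; a higher number here means a weaker inhibitor, a lower number a stronger inhibitor. Compound 1 `O=C1c2ccc(Cl)cc2CN1c1cccnc1` gives 10700 nM. Compound 2 `CCC(=O)N[C@@H]1CCCc2c1cncc2N1C(=O)c2ccc(Cl)cc2[C@@H]1C` gives 414 nM, the second highest of the three numbers, and compound 3 `CC(=O)N[C@@H]1CCCc2c1cncc2N1C(=O)c2ccc(Cl)cc2[C@@H]1C` gives 81 nM. Among the measured compounds shown here, the only single-point step so far, a 5.1-fold lower number from compound 2 to compound 3 (0.71 log units; beyond the scatter), swaps a methyl for hydrogen on a saturated chain carbon bound to a carbonyl carbon. For the measured compounds named here, compound 4 `CCC(=O)N[C@@H]1CCCc2c1cncc2N1Cc2cc(Cl)ccc2C1=O` differs from compound 2 by hydrogen in place of methyl on a saturated ring carbon, a change at a different site, so no measured step bears on it directly; the step to compound 3 shows only that losing a methyl can shift the number modestly. The expected step in this assay is a 1.7-fold higher number from compound 2 to compound 4 (0.23 log units; within the scatter), with no direction firmly predicted. Compound 4 is therefore estimated at 700 nM, likely between 200 nM and 2500 nM.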

Compound 4, half-maximal inhibitory concentration: 5210 nM
Compound 4: middle estimate off by 7.4-fold (0.87 log units), on the low side, and the stated range ends below it.
By their numbers in this assay, from the lowest: compound 3; then compound 2; then compound 4; then compound 1.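

In this assay, hydrogen in place of methyl on this saturated ring carbon gives a 13-fold higher number from compound 2 to compound 4 (1.10 log units; beyond the scatter), a large weakening, whereas the same swap on the chain carbon gave a 5.1-fold lower number from compound 2 to compound 3 (0.71 log units; beyond the scatter), in the opposite direction. Losing a methyl therefore has no single outcome across these compounds, and its result depends on the site. Nothing measured here explains the difference. Going by these compounds, whether an ethyl or a fluorine on this ring carbon would preserve inhibition stays open. So does whether removing the ring methyl would cost as much starting from compound 3.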